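Ethyl to methoxycarbonyl on the shared core

The source may hold more compounds than are shown below. What is called first, only, known or untested is meant among the compounds shown, and "the series" means these compounds.

In an ADME assay on HCT-116 cells (Homo sapiens) for antiproliferative activity (a higher number here means a weaker inhibitor, a lower number a stronger inhibitor), compound 1 `COc1ccc(C(C)=O)cc1COc1ccc(Cl)cc1` gives 39000 nM. Compound 2 `CCc1ccc(OC)c(COc2ccc(Cl)c(C)c2)c1` gives 43000 nM, within the scatter of compound 1. Compound 3 `COc1ccc(C(N)=O)cc1COc1ccc(Cl)cc1` reads > 50000 nM, which is a limit of the assay and not a number.

Compound 4 `COC(=O)c1ccc(OC)c(COc2ccc(Cl)c(C)c2)c1` has methoxycarbonyl in place of ethyl on an aromatic carbon of compound 2: methoxycarbonyl in place of ethyl on an aromatic carbon. Going by the values given here, no measured step makes this exact change. The nearest is an at least 1.2-fold higher number from compound 1 to compound 3 (0.10 log units; that floor lies within the scatter), which also concerns a carbonyl carbon, but it fixes only a floor and gives no firm size. Compound 1 carries a carbonyl group and gives 39000 nM, while compound 2 has none and gives 43000 nM, although these two differ in more than one place. No step beyond the scatter is therefore expected in this assay. The estimated change is a 1.1-fold lower number from compound 2 to compound 4 (0.03 log units; within the scatter). A reading for compound 4 at the limit of > 50000 nM in this assay, at which 1 of the 3 values shown sits, remains possible. For compound 4 the expected value is 40000 nM, with an estimated range of 20000 nM to 70000 nM.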

Compound 4, half-maximal inhibitory concentration: 23000 nM
The estimate for compound 4 lay 1.7-fold (0.24 log units) above the measured number; measured number inside the range.
By their numbers in this assay, from the lowest: compounds 4, 1 and 2 (each within the scatter of the next). At a limit, above all of these: compound 3.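

Going by these compounds alone, this gives the first one-place step with a number at both ends at this aromatic carbon, para to a methoxy group: in this assay, the swap gives a 1.9-fold lower number from compound 2 to compound 4 (0.27 log units; within the scatter). Methoxycarbonyl, with its 4 heavy atoms and 2 hydrogen-bond acceptors, therefore replaces ethyl, with 2 heavy atoms and no hydrogen-bond acceptors, without a step beyond the scatter. Compound 4 gives a measured number and does not sit at the assay limit, which remains a limit and not a number: the limit of > 50000 nM in this assay, at which 1 of the 4 values shown sits.

Going by these compounds, whether a carboxylic acid, an amine or a longer chain on this aromatic carbon gives a step beyond the scatter stays open. With one firm step at this position, no trend across substituents can be drawn here, and no cause for this step can be assigned.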